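The source may hold more compounds than are shown below. What is called first, only, known or untested is meant among the compounds shown, and "the series" means these compounds.

Working notes on the series. Compound 1 `CCC/C=C/C(=O)N(Cc1ccc(OC)c(O)c1)c1cc(OC)c(OC)c(OC)c1` is the reference point. Going by the values given here, in a functional assay on MGC-803 cells (Homo sapiens) for inhibition, read by MTT assay, with a stated time of 48 h (on this read-out higher numbers stand for weaker inhibition and lower numbers for stronger inhibition), compound 1 gives 70 nM, the lowest of the two numbers so far. Compound 2 `COc1ccc(CNc2cc(OC)c(OC)c(OC)c2)cc1N` keeps the shared core but differs from compound 1 in more than one place; in this assay compound 2 gives 7970 nM, a much higher number, beyond the scatter, and no single step can be read from this pair. Compound 3 `C=CC(=O)N(Cc1ccc(OC)c(O)c1)c1cc(OC)c(OC)c(OC)c1` is the next compound to be measured. It differs from compound 1 in one place: vinyl in place of pent-1-en-1-yl on a carbonyl carbon. The carbonyl and the amide-type nitrogen are kept, so only the length of the chain on the carbonyl carbon changes. Among the compounds with values here, no measured pair shows what this change does. In this assay the expected step is a 1.3-fold higher number from compound 1 to compound 3 (0.11 log units; within the scatter), small and with no direction beyond the scatter. Compound 3 is therefore expected to give 90 nM in this assay, within 25 nM to 350 nM.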

Compound 3, half-maximal inhibitory concentration: 62 nM
Compound 3: the middle estimate sits 1.5-fold (0.16 log units) above what was measured; low and high end bracket the measured number.
By their numbers in this assay, from the lowest: compounds 3 and 1 (each within the scatter of the next); then compound 2.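

Going by these compounds alone, the first single-place step falls on the carbonyl carbon: in this assay, there is a 1.1-fold lower number from compound 1 to compound 3 (0.05 log units; within the scatter), so pent-1-en-1-yl and vinyl cannot be told apart on this read-out. Going from 5 heavy atoms to 2 in the group on the carbonyl carbon, with the one double bond outside aromatic rings present in both groups, leaves the number within the scatter for this pair. No supporting evidence bears on this result.

From the compounds shown here alone, what an ethyl group, which lacks that double bond, or a longer chain would give at this position remains open. Also open, going by these compounds, is which of the several differences between compound 1 and compound 2 carries the gap between them, as no step can be read for that pair.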